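This account rests on a few compounds, and the source may have more. Where it says the series, first, only, none or still open, it means among the compounds named here.

Working notes on the series, read in a functional assay on P388 cells (Mus musculus) for inhibition; a higher number here means that more compound is needed for the effect, a lower number that less compound is needed. For the measured compounds named here, compound 1 `Nc1nc(Cl)c2ncn(C3C=CC(CO)C3)c2n1` gives 75 ug/mL, the only true number available so far. Compound 2 `Nc1nc(Cl)c2ncn(C3CCC(CO)C3)c2n1` gives > 100 ug/mL, which is a limit of the assay and not a number. Going by the values given here, the one other reference point is therefore (the limit of > 100 ug/mL in this assay, at which 1 of the 2 values shown sits), and the pair offers no measured step to work from.

The next compound is compound 3 `Nc1nc(N)c2ncn(C3C=CC(CO)C3)c2n1`, which keeps the core of compound 1 and carries one exchange, amino in place of chloro on an aromatic carbon. Among the compounds with values here, no measured pair covers this exchange, so the expectation is anchored only on compound 1 at 75 ug/mL. In this assay, within the data shown here, no step clearly beyond the usual scatter is expected, with a slight lean towards less compound being needed. The expected change is a 1.5-fold lower number from compound 1 to compound 3 (0.18 log units; within the scatter). A reading that reaches only the limit of the assay would not be a surprise. For compound 3 the estimated value is 50 ug/mL, with an expected range of 15 ug/mL to 110 ug/mL.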

Compound 3, concentration for half-maximal effect: > 100 ug/mL
Compound 3 ended at the assay's limit; the forecaster's own chance of this, stated with the estimate: 25%; at least 2.0-fold (0.30 log units) between middle value and limit.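

In this assay, amino in place of chloro on an aromatic carbon, next to the ring nitrogen, gives an at least 1.3-fold higher number from compound 1 to compound 3 (0.12 log units; that floor lies within the scatter), the first step measured at this position, and it is only a floor, not a size. For the compounds shown here, the reading does not show the exchange lowering the number, and compound 1, at 75 ug/mL, remains the only compound with a true number. The reading for compound 3 is a limit of the assay and not a number, and the series now rests largely on that limit: the limit of > 100 ug/mL in this assay, at which 2 of the 3 values shown sit.

From the compounds shown here alone, how far compound 3 lies beyond the limit stays open, and so does whether the true step from the chloro compound to the amino compound lies beyond the usual scatter. Also open, going by these compounds, is how other groups at this position, such as a hydroxyl, a methoxy or a methylamino group, would read on the core of compound 1, and whether any of them would give a true number rather than another limit.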